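Sigma-1 binding notes: the group on the ring nitrogen

This account rests on a few compounds, and the source may have more. Where it says the series, first, only, none or still open, it means among the compounds named here.

Measured so far:
compound 1 `Fc1ccc(C(SCCNC2CCN(Cc3ccccc3)CC2)c2ccc(F)cc2)cc1` 3.81 nM
compound 2 `Fc1ccc(C(SCCNC2CCN(Cc3ccc(Cl)cc3)CC2)c2ccc(F)cc2)cc1` 45.5 nM
compound 3 `OC(Cc1ccccc1)CN1CCC(NCCSC(c2ccc(F)cc2)c2ccc(F)cc2)CC1` 309 nM

In an assay on membranes from Cortex for displacement of a labelled ligand from Sigma non-opioid intracellular receptor 1 (Cavia porcellus), read by scintillation counting, with a stated time of 120 min (a lower number here means a stronger inhibitor, a higher number a weaker inhibitor), compound 3 stands at the highest number of the three: an 81-fold higher number from compound 1 to compound 3 (1.91 log units; beyond the scatter) and a 6.8-fold higher number from compound 2 to compound 3 (0.83 log units; beyond the scatter). Compound 4 `O=C(c1ccccc1)N1CCC(NCCSC(c2ccc(F)cc2)c2ccc(F)cc2)CC1` differs from compound 3 by benzoyl in place of 2-hydroxy-3-phenylpropyl on an amine nitrogen in a ring. Going by the values given here, no measured step introduces a benzoyl on this nitrogen, so there is no direct precedent. Both steps that end at compound 3 change the group on this same nitrogen, and both were beyond the scatter, so the position is sensitive and a clear step is expected here too. The direction is uncertain; on balance a lower number than compound 3 is expected for compound 4, a 3.1-fold lower number from compound 3 to compound 4 (0.49 log units; beyond the scatter), giving an estimate of 100 nM with a range from 10 nM to 1000 nM.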

Compound 4, inhibition constant: 2.03 nM
The estimate for compound 4 lay 49-fold (1.69 log units) above the measured number; measured number below the stated range.
By their numbers in this assay, from the lowest: compounds 4 and 1 (each within the scatter of the next); then compound 2; then compound 3.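

In this assay, benzoyl on the ring nitrogen gives a far lower number than either 2-hydroxy-3-phenylpropyl (a 150-fold lower number from compound 3 to compound 4 (2.18 log units; beyond the scatter)) or 4-chlorobenzyl (a 22-fold lower number from compound 2 to compound 4 (1.35 log units; beyond the scatter)). Benzoyl and benzyl cannot be separated (a 1.9-fold lower number from compound 1 to compound 4 (0.27 log units; within the scatter)), so this position tolerates a carbonyl in place of the benzyl carbon, and a high number does not follow from every change on this nitrogen. No measurement offered here explains these steps.

Open, on these data alone, is whether chloro on the benzoyl ring would cost as much as on benzyl. Also open, as far as these compounds go, is whether acetyl, with no aromatic ring, or 2-phenylethyl, with a longer chain, would keep the number low.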